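The source may report more compounds than this note shows. Statements on the series, on what has been measured and on what is new or still open speak of the compounds shown alone.

Working notes on the series, read in an ADME assay on HEK-293T cells (Homo sapiens) for inhibition, read by CCK-8 assay, with a stated time of 48 h, tested at 20 uM; on this read-out higher numbers stand for more inhibition of growth at the one concentration tested and lower numbers for less inhibition of growth. Compound 2 (`N#C/C(=C\c1ccccc1OS(=O)(=O)c1ccc([N+](=O)[O-])cc1)C(=O)Nc1nnc(Cc2ccccc2)s1`) has no single number and stands as "not toxic" (no number reported), so the step from it has no numerical starting point. Going by the values given here, its two measured neighbours give the only numbers nearby: compound 1 (`Cc1ccc(S(=O)(=O)Oc2ccccc2/C=C(\C#N)C(=O)Nc2nnc(Cc3ccccc3)s2)cc1`) gives 15% and compound 3 (`N#C/C(=C\c1ccccc1OS(=O)(=O)c1ccc(F)cc1)C(=O)Nc1nnc(Cc2ccccc2)s1`) gives 6%.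

The step under consideration leads to compound 4 (`N#C/C(=C\c1ccccc1OS(=O)(=O)c1ccc([N+](=O)[O-])cc1)C(=O)Nc1nnc(Cc2cccc(F)c2)s1`), with the change (fluoro in place of hydrogen on an aromatic carbon). In words, this is fluoro in place of hydrogen on an aromatic carbon, turning the benzyl group into 3-fluorobenzyl, while the rest of compound 2 stays as it is.

Among the compounds with values here, only one measured step bears on this, and only loosely: a number 9 percentage points lower from compound 1 to compound 3 (within the scatter). That step also brings in a fluoro, but it replaces methyl rather than hydrogen and sits at a different aromatic carbon. Within the data shown here, no measured step touches the benzyl group, so the data give no direct precedent for this change.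

On that single step, no shift beyond the scatter is expected in this assay, and compound 4 should stay in the low range seen so far. For compound 4 the estimated value is 9%, with an expected range from 0% to 22%.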

Compound 4, percent growth inhibition at one concentration: "not toxic" (no number reported)
No number was reported for compound 4; the estimate stays without a comparison.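

In this assay compound 2 stands as "not toxic" (no number reported) and compound 4 as "not toxic" (no number reported) so no step can be read between the two. The compounds shown leave open whether 3-fluorobenzyl in place of benzyl shifts growth inhibition on this read-out at all. No measurement at hand bears on an explanation of this result.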